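This account rests on a few compounds, and the source may have more. Where it says the series, first, only, none or still open, it means among the compounds named here.

Measured so far:
- Compound 1 `COc1cccc(-c2nc3c(-c4ccc(Cl)cc4)n[nH]c3c(=O)n2NC(=O)c2ccccc2)c1`: in a functional assay on DU-145 cells (Homo sapiens) for cytotoxicity, read by sulforhodamine B assay, with a stated time of 2 days, tested at 100 uM (a lower number here means less inhibition, a higher number more inhibition at the concentration tested (going by the name of the read-out)), compound 1 gives 94.1%.
- Compound 2 `O=C(Nn1c(CCC2CCCC2)nc2c(-c3ccc(Cl)cc3)n[nH]c2c1=O)c1ccccc1`: in this assay compound 2 gives 89.6%.

Compound 2 stands at the bottom of these two numbers only nominally: the step of a number 4.5 percentage points lower from compound 1 to compound 2 (within the scatter) lies within the scatter, so the two compounds cannot be told apart on the evidence shown. Compound 3 `CC(C)(C)c1ccc(C(=O)Nn2c(CCC3CCCC3)nc3c(-c4ccc(Cl)cc4)n[nH]c3c2=O)cc1` is the next compound, differing from compound 2 by tert-butyl in place of hydrogen on an aromatic carbon; read one bond further out, benzoyl becomes (4-(tert-butyl)phenyl)carbonyl. Among the measured compounds shown here, no measured step touches this part of the molecule: the only step available, a number 4.5 percentage points lower from compound 1 to compound 2 (within the scatter), alters the 2-cyclopentylethyl side and was itself within the scatter. For the measured compounds named here, with both measured numbers high and no step pointing either way, the step of a number 1.6 percentage points lower from compound 2 to compound 3 (within the scatter) is expected to remain within the scatter. Compound 3 is therefore estimated at 88% in this assay, with a range of 70% to 98%.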

Compound 3, a percentage reported as inhibition, at one concentration (the size of the read-out at that concentration, not a potency): 64.2%
The estimate for compound 3 lay 23.8 percentage points above the measured number; measured number outside the range, below it.
By their numbers in this assay, from the lowest: compound 3; then compounds 2 and 1 (each within the scatter of the next).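

In this assay, among the compounds shown here, the benzoyl end of the molecule is the first place where a single change reads beyond the scatter: tert-butyl in place of hydrogen, on an aromatic carbon para to a large group, gives a number 25.4 percentage points lower from compound 2 to compound 3 (beyond the scatter). For the compounds shown here, the only earlier step, a number 4.5 percentage points lower from compound 1 to compound 2 (within the scatter), changed the other side of the molecule and could not be read as a change at all, so the number does move with substitution on this ring. Nothing available bears on the reason for this fall.

Going by these compounds, whether the fall belongs to tert-butyl specifically or to any group at this place stays open, since a methyl, a chlorine, an amine or a carboxylic acid on the same carbon would separate the two readings. Also open, on these data alone, is whether the same change would lower the number with 3-methoxyphenyl in place of 2-cyclopentylethyl.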